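Replacing an aromatic ring with a saturated one

A few compounds are considered here, and "the series" means these few. Any claim that something is new, unique, unknown or untested is made for them only; others in the source may bear on it.

compound 1 `CCCCc1cnc(C(C)Cc2ccc(-c3ccccc3C(=O)O)cc2)[nH]1`: 2760 nM
compound 2 `O=C(O)c1ccccc1-c1ccc(CCc2ncc(Cc3cccc(F)c3)[nH]2)cc1`: 159 nM
compound 3 `CCCCc1cnc(/C=C/c2ccc(-c3ccccc3C(=O)O)cc2)[nH]1`: 4380 nM

In an in vitro functional assay on cells for agonist activity at Bombesin receptor subtype-3 (Homo sapiens), read by luminescence and calcium flux (a higher number here means that more compound is needed for the effect, a lower number that less compound is needed), compound 2 holds the lowest number of the three shown, with compound 1 and compound 3 both well beyond the scatter above it. Compound 4 `O=C(O)c1ccccc1-c1ccc(CCc2ncc(CC3CCCCCC3)[nH]2)cc1` has not yet been measured. It differs from compound 2 in one place: cycloheptyl in place of 3-fluorophenyl on a saturated chain carbon bound to an aromatic carbon. Among the measured compounds shown here, no measured pair shows this kind of change, so no step can be read off. Because compound 2 gives 159 nM, the expectation is that compound 4 loses some potency, with a step of a 2.5-fold higher number from compound 2 to compound 4 (0.40 log units; beyond the scatter) that is estimated to lie just beyond the scatter. For compound 4 the estimate is 400 nM, in a range from 100 nM to 1600 nM.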

Compound 4, half-maximal effective concentration: 88 nM
For compound 4 the middle estimate is 4.5-fold (0.66 log units) above the measured one; measured number outside the range, below it.
By their numbers in this assay, from the lowest: compounds 4 and 2 (each within the scatter of the next); then compounds 1 and 3 (each within the scatter of the next).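

In this assay there is a 1.8-fold lower number from compound 2 to compound 4 (0.26 log units; within the scatter) when cycloheptyl takes the place of 3-fluorophenyl, so the two compounds cannot be told apart. On this saturated chain carbon, an aromatic ring carrying fluorine is therefore not required: in this pair, a non-aromatic ring of carbon only serves equally well. Nothing at hand accounts for this result.

Still open, on these data alone, is whether cyclopentyl, or a ring holding an amine such as piperidinyl, would read the same here. A single pair also cannot show whether this swap holds on other cores.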